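Para substituent swaps on the imidazole series, compound 4 outlook

This account rests on a few compounds, and the source may have more. Where it says the series, first, only, none or still open, it means among the compounds named here.

Measured in a functional assay on HEK293 cells for agonist activity at Bombesin receptor subtype-3 (Homo sapiens), read by luminescence and calcium flux, with a stated time of 10 min; on this read-out lower numbers stand for an effect already at smaller amounts and higher numbers for an effect only at larger amounts of compound:
compound 1 `CCC(C)(C)Cc1c[nH]c(CCc2ccc(-c3cccc(C)n3)cc2)n1` gives 102 nM
compound 2 `CCC(C)(C)Cc1c[nH]c(CCc2ccc(-c3ccccc3C(=O)O)cc2)n1` gives 101 nM
compound 3 `CCC(C)(C)Cc1c[nH]c(CCc2ccc(N3CCCCC3)cc2)n1` gives 108 nM

Compound 3 sits on the same level as the other two: a 1.1-fold higher number from compound 1 to compound 3 (0.02 log units; within the scatter) and a 1.1-fold higher number from compound 2 to compound 3 (0.03 log units; within the scatter), both within the scatter, as is a 1.0-fold lower number from compound 1 to compound 2 (0.00 log units; within the scatter). Three quite different groups at this position of the shared core of compound 3 thus give numbers that cannot be told apart.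

The step to compound 4 `CCC(C)(C)Cc1c[nH]c(CCc2ccc(-c3ccns3)cc2)n1` is 1,2-thiazol-5-yl in place of piperidin-1-yl on an aromatic carbon. Within the data shown here, none of the measured steps involves a five-membered aromatic ring at this position, so the nearest guidance is that an aromatic six-membered ring with one ring nitrogen, an aromatic ring bearing a carboxylic acid and a saturated ring attached through nitrogen all land together. On that basis no step beyond the scatter is expected in this assay, so a 1.0-fold lower number from compound 3 to compound 4 (0.01 log units; within the scatter) is estimated. Compound 4 is therefore expected at 105 nM, with a range from 40 nM to 280 nM.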

Compound 4, half-maximal effective concentration: 102 nM
Beside the measured number, compound 4's estimate is 1.0-fold (0.01 log units) above it; measured number inside the range.
By their numbers in this assay, from the lowest: compounds 2, 1, 4 and 3 (each within the scatter of the next).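

In this assay, a five-membered aromatic ring with 2 hetero atoms, sulfur among them, joins the groups tolerated at this position, on an aromatic carbon para to a large group: replacing piperidin-1-yl gives (a 1.1-fold lower number from compound 3 to compound 4 (0.02 log units; within the scatter)), replacing 2-carboxyphenyl gives (a 1.0-fold higher number from compound 2 to compound 4 (0.00 log units; within the scatter)) and replacing 6-methylpyridin-2-yl gives (no change at the digits printed from compound 1 to compound 4 (within the scatter)). All three steps lie within the scatter, so neither ring size nor a ring sulfur separates compound 4 from compounds 1, 2 and 3. Nothing available explains this flat response.

As far as these compounds go, all four groups at this position are rings, so a primary amine, a longer alkyl chain or plain hydrogen there remains open. Also open, from the compounds shown here alone, is whether the same flat response holds when another part of the shared core changes.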